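Oxadiazolone in Place of Oxadiazole on a Pyrrolidine Core

The compounds below may be only part of what the source reports. "The series", "measured", "known", "first", "only" and "open" are said of these compounds alone.

Of the compounds shown here, two sharing one core have been measured. Compound 1 `COCCNC(=O)C1CCN(c2ccc(Cl)c(C(F)(F)F)c2)C1` gives 3500 nM in an assay on cells for inhibition of Palmitoleoyl-protein carboxylesterase NOTUM variant C330S (Homo sapiens), read by fluorescence, with a stated time of 40 min; on this read-out lower numbers stand for stronger inhibition and higher numbers for weaker inhibition. Compound 2 `FC(F)(F)c1cc(N2CCC(c3nnco3)C2)ccc1Cl` gives 24000 nM in this assay and stands highest of the two numbers, meaning it is the weaker inhibitor. Among the measured compounds shown here, the single step joining them, a 6.9-fold higher number from compound 1 to compound 2 (0.84 log units; beyond the scatter), came with a 1,3,4-oxadiazol-2-yl in place of (2-methoxyethyl)carbamoyl on a saturated ring carbon.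

Compound 3 `O=c1[nH]nc(C2CCN(c3ccc(Cl)c(C(F)(F)F)c3)C2)o1` is the next compound. It differs from compound 2 by a group of 6 heavy atoms (2 carbon, 2 nitrogen, 2 oxygen; one five-membered aromatic ring with 3 hetero atoms) in place of a group of 5 heavy atoms (2 carbon, 2 nitrogen, 1 oxygen; one five-membered aromatic ring with 3 hetero atoms), on a saturated ring carbon; the entering ring carries one hydrogen-bond donor and one double bond outside aromatic rings, while the leaving ring carries neither. For the measured compounds named here, no measured step covers this exact exchange. Going by the values given here, the only measured step is from compound 1 to compound 2, where the group carrying a carbonyl and a hydrogen on nitrogen gave the lower number; this offers a loose hint but not a direct precedent. A small step toward a lower number is therefore expected for compound 3, estimated as a 2.0-fold lower number from compound 2 to compound 3 (0.30 log units; within the scatter), while a result within the scatter would not be surprising. The estimate for compound 3 in this assay is 12000 nM, with a range from 3500 nM to 40000 nM.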

Compound 3, half-maximal inhibitory concentration: 4200 nM
Estimate against measurement, compound 3: 2.9-fold (0.46 log units) above; the range from low to high includes it.
By their numbers in this assay, from the lowest: compounds 1 and 3 (each within the scatter of the next); then compound 2.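

Exchanging one five-membered aromatic ring for another on this saturated ring carbon is not a neutral swap in this assay: the 1,3,4-oxadiazol-2-yl group gives way to a ring with one more oxygen, 1 hydrogen-bond donor and 1 double bond outside aromatic rings, and the result is a 5.7-fold lower number from compound 2 to compound 3 (0.76 log units; beyond the scatter). The same ring stands level with the open (2-methoxyethyl)carbamoyl chain, with a 1.2-fold higher number from compound 1 to compound 3 (0.08 log units; within the scatter). Among these few compounds the two groups holding both a carbonyl and a hydrogen on nitrogen read alike, with only compound 2, which lacks them, apart. Nothing available explains why these few added atoms shift the number so clearly.

As far as these compounds go, it remains open whether the carbonyl or the hydrogen on nitrogen matters more, which a methyl group on that ring nitrogen, or an amine on the 1,3,4-oxadiazole ring, could begin to separate. From the compounds shown here alone, it is also open how a carboxylic acid on this same ring carbon would compare with compound 1 and compound 3.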